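The compounds below may be only part of what the source reports. "The series", "measured", "known", "first", "only" and "open" are said of these compounds alone.

Measured compounds in a functional assay on HT-29 cells (Homo sapiens) for cytotoxicity, read by MTT assay, with a stated time of 24 h, tested at 0.64 ug/mL; a higher number here means a stronger effect of the compound at the concentration tested, a lower number a weaker effect:
compound 1 `Cc1ccc2oc(SCC(=O)Nc3ccc(-c4nc(-c5ccccc5)c(-c5ccccc5)n4C)cc3)nc2c1` gives 11%
compound 2 `Cn1nnnc1SCC(=O)Nc1ccc(-c2nc(-c3ccccc3)c(-c3ccccc3)n2C)cc1` gives 38%

Compound 2 stands highest of the two numbers in this assay; its nearest neighbour is compound 1, and the step of a number 27 percentage points higher from compound 1 to compound 2 (beyond the scatter) is beyond the scatter, with the change being one heteroaryl group for another on the sulfur.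

Compound 3 `CCN1CCN(CC(=O)Nc2ccc(-c3nc(-c4ccccc4)c(-c4ccccc4)n3C)cc2)CC1` is not yet measured. It differs from compound 2 in the following way: 4-ethylpiperazin-1-yl in place of (1-methyl-1H-tetrazol-5-yl)sulfanyl on a saturated chain carbon bound to a carbonyl carbon. Going by the values given here, no measured step bears directly on this change, since the only step keeps the sulfanyl link and exchanges the ring on it, whereas here the sulfur and its ring leave together and a saturated ring enters. The single step available was modest in size, so a step of similar or smaller size is plausible in either direction; on the numbers shown the direction cannot be fixed.

Compound 3 is expected to give 25% in this assay, with a range from 5% to 55%. The step of a number 13 percentage points lower from compound 2 to compound 3 (beyond the scatter) is the estimated outcome, and the range is wide because only a number 27 percentage points higher from compound 1 to compound 2 (beyond the scatter) is known and it does not cover this kind of change.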

Compound 3, a percentage reported as activity, at one concentration (the size of the read-out at that concentration, not a potency): 7.4%
For compound 3 the middle estimate is 17.6 percentage points above the measured one; the range from low to high includes it.
By their numbers in this assay, from the lowest: compounds 3 and 1 (each within the scatter of the next); then compound 2.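

In this assay, the replacement of the whole sulfanyl unit by a saturated ring on a saturated chain carbon bound to a carbonyl carbon gives a number 30.6 percentage points lower from compound 2 to compound 3 (beyond the scatter), so the reading of compound 2 does not survive this change. Starting instead from (5-methyl-1,3-benzoxazol-2-yl)sulfanyl, the same kind of replacement gives a number 3.6 percentage points lower from compound 1 to compound 3 (within the scatter), which leaves (1-methyl-1H-tetrazol-5-yl)sulfanyl as the only one of the three groups at this position set apart by its number. No measurement shown here accounts for this outcome.

The compounds shown leave open whether the reading of compound 2 follows the sulfur or the tetrazole ring, a question that 1-methyl-1H-tetrazol-5-yl joined through an amine nitrogen would address. From the compounds shown here alone, whether the ethyl group matters is also open, and a morpholine or an unsubstituted piperazine at this position would bear on that.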